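Estimating a Cytotoxicity Value After One Side-Group Swap

The compounds below may be only part of what the source reports. "The series", "measured", "known", "first", "only" and "open" are said of these compounds alone.

Going by the values given here, in an ADME assay on A549 cells (Homo sapiens) for cytotoxicity, read by resazurin assay, with a stated time of 48 h (on this read-out higher numbers stand for lower toxicity in this test and lower numbers for higher toxicity in this test), compound 2 (`O=C(Nc1ccc(N(CC2CC2)CC2CC2)cc1Cl)c1cc(Cl)ccc1O`) gives 12800 nM, the lower of the two numbers measured so far. Compound 1 (`CN(C)c1ccc(NC(=O)c2cc(Cl)ccc2O)c(Cl)c1`) gives 85100 nM. Compound 3 (`O=C(Nc1ccc(NCc2ccc(Cl)cc2)cc1Cl)c1cc(Cl)ccc1O`) has not been measured yet. It has (4-chlorobenzyl)amino in place of bis(cyclopropylmethyl)amino on an aromatic carbon. Among the compounds with values here, only one measured step involves a change of the group at this place, and it is a 6.6-fold lower number from compound 1 to compound 2 (0.82 log units; beyond the scatter). That step replaced dimethylamino with bis(cyclopropylmethyl)amino, a different exchange from the one here, and a single step shows no trend. A small further drop is therefore expected, with no large shift in either direction. The expected step in this assay is a 1.5-fold lower number from compound 2 to compound 3 (0.18 log units; within the scatter). The estimate for compound 3 is 8500 nM, within an expected range of 2800 nM to 26000 nM.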

Compound 3, half-maximal cytotoxic concentration: 59700 nM
The estimate for compound 3 lay 7.0-fold (0.85 log units) below the measured number; the whole stated range lies below it.
By their numbers in this assay, from the lowest: compound 2; then compounds 3 and 1 (each within the scatter of the next).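

In this assay putting (4-chlorobenzyl)amino where bis(cyclopropylmethyl)amino stood brings a 4.7-fold higher number from compound 2 to compound 3 (0.67 log units; beyond the scatter) even though both groups count the same number of heavy atoms, so an equal count does not mean an equal result at this place. Against dimethylamino, the new group gives a 1.4-fold lower number from compound 1 to compound 3 (0.15 log units; within the scatter) and so the lower number of compound 2 is not shared by compound 3. Among these three compounds, the lower number goes with bis(cyclopropylmethyl)amino alone.

On these data alone, the aromatic ring, the ring chlorine and the hydrogen on the nitrogen all enter together in compound 3, so their separate shares remain open. A plain benzylamino group without the chlorine, or a single cyclopropylmethylamino group, would help to pull these apart. Nothing measured here bears on what lies behind these differences.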